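The compounds below may be only part of what the source reports. "The series", "measured", "known", "first", "only" and "open" are said of these compounds alone.

In a functional assay on PC-3 cells (Homo sapiens) for inhibition, read by sulforhodamine B assay, with a stated time of 48 h, tested at 50 uM (a lower number here means less inhibition of growth, a higher number more inhibition of growth at the concentration tested), compound 2 (`COc1ccc([C@@H]2C/C(=N/OCc3cn(-c4ccc(O)cc4)nn3)c3cc(CC=C(C)C)c(OC)cc3O2)cc1`) gives 64%. Compound 3 (`COc1ccc([C@@H]2CC(=O)c3cc(CC=C(C)C)c(OC)cc3O2)cc1`) gives 58%. The gap between compound 2 and compound 3 lies within the scatter. Compound 1 (`COc1cc2c(cc1CCC(C)C)C(=O)C[C@@H](c1ccc(O)cc1)O2`) gives 78%. The gap between compound 2 and compound 1 lies beyond the scatter, with compound 1 the higher of the two. Compound 2 therefore sits in the middle of a small set of three numbers, with no clear separation from compound 3.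

Compound 4 (`COc1ccc([C@@H]2C/C(=N/OCc3cn(-c4ccc(C(=O)c5ccccc5)cc4)nn3)c3cc(CC=C(C)C)c(OC)cc3O2)cc1`) has not yet been measured. It differs from compound 2 at one place: benzoyl in place of hydroxy on an aromatic carbon. In words, benzoyl stands in place of hydroxy on an aromatic carbon, para to a large group.

For the measured compounds named here, no measured pair isolates this change or any other single change, so no step in this assay can be carried over directly. Going by the values given here, the expectation starts from compound 2 at 64%, and with only three measured compounds, the range has to stay wide. No shift beyond the scatter is expected, in either direction. The estimated step, a number 4 percentage points lower from compound 2 to compound 4 (within the scatter), is expected to remain within the scatter. For compound 4 the estimated value is 60%, with an expected range from 42% to 78%.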

Compound 4, percent growth inhibition at one concentration: 40%
Compound 4: middle estimate off by 20 percentage points, on the high side, and the stated range ends above it.
By their numbers in this assay, from the lowest: compound 4; then compounds 3 and 2 (each within the scatter of the next); then compound 1.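

In this assay, for the compounds shown here, benzoyl in place of hydroxy on an aromatic carbon, para to a large group, gives a number 24 percentage points lower from compound 2 to compound 4 (beyond the scatter), the first single-place step and a sign that growth inhibition at the concentration tested depends on what this carbon carries. The change replaces a group with a hydrogen-bond donor by one with none and also brings in a six-membered aromatic ring of carbon only and a carbonyl, so this one step cannot assign the drop to any one of these differences. No accompanying measurement bears on the reason for the step.

Still open, on these data alone, is whether the drop comes from losing hydroxy or from adding benzoyl, which a methoxy or a plain phenyl on the same carbon would help to separate. An amine or a carboxylic acid at this place would show whether other groups stay close to compound 2 or also fall away as compound 4 does.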